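The source may report more compounds than this note shows. Statements on the series, on what has been measured and on what is new or still open speak of the compounds shown alone.

Measured in an assay for inhibition of serine/threonine-protein kinase PLK2 (Homo sapiens), read by FRET and Z'-LYTE, with a stated time of 1 h; on this read-out lower numbers stand for stronger inhibition and higher numbers for weaker inhibition:

compound 1 `CCC1C(=O)N(C)c2cnc(Nc3ccc(S(=O)(=O)NCC(C)C)cc3)nc2N1c1ccn(C)n1`: 311 nM
compound 2 `CCC1C(=O)N(C)c2cnc(-n3ccc4cc(C(=O)NC(C)C)ccc43)nc2N1c1ccn(C)n1`: 125 nM
compound 3 `CCCCNS(=O)(=O)c1ccc(Nc2ncc3c(n2)N(C2CCCC2)[C@H](CC)C(=O)N3C)cc1`: 19.9 nM

Compound 3 has the lowest of the three numbers, and its distance to compound 2 and to compound 1 is beyond the scatter in each case, so of these three compounds it is the strongest inhibitor. Compound 4 `CC[C@@H]1C(=O)N(C)c2cnc(Nc3ccc(S(=O)(=O)NC4CCCC4)cc3)nc2N1C1CCCC1` is not yet measured. It differs from compound 3 in one place: cyclopentyl in place of butyl on a sulfonamide nitrogen. Among the compounds with values here, the two groups are close in size and carry neither donors nor acceptors, and nothing among the measured compounds tests this exchange. No step beyond the scatter is expected in this assay from compound 3 to compound 4; the expected step is a 1.0-fold higher number from compound 3 to compound 4 (0.00 log units; within the scatter). Compound 4 is therefore estimated at 20 nM, within a range from 8 nM to 50 nM.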

Compound 4, half-maximal inhibitory concentration: 23.9 nM
Beside the measured number, compound 4's estimate is 1.2-fold (0.08 log units) below it; the measured number falls inside the stated range.
By their numbers in this assay, from the lowest: compounds 3 and 4 (each within the scatter of the next); then compound 2; then compound 1.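

On this sulfonamide nitrogen, an open butyl chain and a cyclopentyl ring are interchangeable in this assay, with a 1.2-fold higher number from compound 3 to compound 4 (0.08 log units; within the scatter) as the step. Within the data shown here, with the rest of the molecule held constant, this is the first direct test of this position, and a ring of carbon serves here as well as a chain of carbon. No supporting measurement shows why the two groups read alike.

Still open, on these data alone, is how this nitrogen responds to a group carrying an amine or a carboxylic acid. A longer chain, such as octyl, is also untested.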